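The source may hold more compounds than are shown below. What is called first, only, known or untested is meant among the compounds shown, and "the series" means these compounds.

Measured so far in a functional assay on CRL2813 cells (Homo sapiens) for cytotoxicity, read by sulforhodamine B assay, with a stated time of 5 days; on this read-out higher numbers stand for weaker inhibition and lower numbers for stronger inhibition:
- compound 1 `O=C(Nc1ccc(I)cc1)N[C@H]1CC[C@H](Oc2ccc(F)cc2)CC1`: 10200 nM
- compound 2 `Cc1cccc(NC(=O)N[C@H]2CC[C@H](Oc3ccc(F)cc3)CC2)c1`: 14400 nM
- compound 3 `O=C(Nc1ccccc1Cl)N[C@H]1CC[C@H](Oc2ccc(F)cc2)CC1`: 9100 nM

All three share the same core and differ only in the aryl group on the amide-type nitrogen. Compound 1 stands second highest of the three numbers; its nearest neighbour is compound 3 (a 1.1-fold lower number from compound 1 to compound 3 (0.05 log units; within the scatter)) and its furthest is compound 2 (a 1.4-fold higher number from compound 1 to compound 2 (0.15 log units; within the scatter)), so every measured compound sits within the scatter of every other, and no order among them can be read from these values.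

Compound 4 `O=C(Nc1ccccc1I)N[C@H]1CC[C@H](Oc2ccc(F)cc2)CC1` is the unmeasured one. It differs from compound 1 in one place: 2-iodophenyl in place of 4-iodophenyl on an amide-type nitrogen.

Within the data shown here, the measured step most relevant to this change is the one from compound 1 to compound 3, where a 4-iodophenyl is exchanged for a 2-chlorophenyl, a 1.1-fold lower number from compound 1 to compound 3 (0.05 log units; within the scatter). The step from compound 2 to compound 3, which also brings in a 2-chlorophenyl, is a 1.6-fold lower number from compound 2 to compound 3 (0.20 log units; within the scatter). Both aryl exchanges on this nitrogen have left this assay unmoved beyond the scatter, and the change to a 2-iodophenyl is of the same kind. Moving the iodine within the ring is therefore expected to give no step beyond the scatter, a 1.1-fold lower number from compound 1 to compound 4 (0.03 log units; within the scatter).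

For compound 4 the expected value in this assay is 9500 nM, with a range from 4500 nM to 20000 nM.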

Compound 4, half-maximal inhibitory concentration: > 20000 nM
Compound 4: only a limit was reported (the forecaster's own chance of this, stated with the estimate: 5%); at least 2.1-fold (0.32 log units) between middle value and limit.
By their numbers in this assay, from the lowest: compounds 3, 1 and 2 (each within the scatter of the next). At a limit, above all of these: compound 4.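

Compound 4 is known only through a limit in this assay: the limit of > 20000 nM in this assay, at which 1 of the 4 values shown sits. Iodo in place of chloro on an aromatic carbon gives an at least 2.1-fold higher number from compound 3 to compound 4 (0.34 log units; beyond the scatter), which is printed as beyond the scatter, so exchanges on this aryl group are not all silent in this series, as the steps among compounds 1, 2 and 3 alone had left it looking. The other two steps, an at least 1.9-fold higher number from compound 1 to compound 4 (0.29 log units; that floor lies within the scatter) and an at least 1.3-fold higher number from compound 2 to compound 4 (0.14 log units; that floor lies within the scatter), have floors that lie within the scatter, so moving from 4-iodophenyl to 2-iodophenyl cannot yet be called a real change on its own, although these floors leave room for a larger one.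

The compounds shown leave open the true value of compound 4, and with it the full size of all three steps. They also leave open whether a 2-bromophenyl would read with compound 3 or with compound 4, and whether an aryl group carrying an amine or a carboxylic acid on this amide-type nitrogen would move the number at all.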